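Adding a Methyl Group Where Cytotoxicity Shows Only Limits

The source may report more compounds than this note shows. Statements on the series, on what has been measured and on what is new or still open speak of the compounds shown alone.

Compound 2 `CCc1nc(-c2ccc(OCCC(C)CCN3CCN(c4ccncc4)C3=O)cc2)no1` and compound 1 `CCCc1nc(-c2ccc(OCCC(C)CCN3CCN(c4ccncc4)C3=O)cc2)no1` share a core and differ by methyl in place of hydrogen on a saturated chain carbon, two bonds along the chain from an aromatic carbon. In an ADME assay on cells (Homo sapiens) for cytotoxicity (on this read-out higher numbers stand for lower toxicity in this test and lower numbers for higher toxicity in this test), compound 2 gives > 25000 nM, which is a limit of the test rather than a number. Compound 1 gives > 12500 nM, also a limit. The step that the two limits leave unreadable from compound 2 to compound 1 therefore has no readable size; the limit of > 12500 nM in this assay, at which 1 of the 3 values shown sits, and the limit of > 25000 nM in this assay, at which 2 of the 3 values shown sit, show where these values sit. Compound 3 `CC(CCCN1CCN(c2ccncc2)C1=O)COc1ccc(-c2ccc(Cl)cc2)cc1` has a different core, and the difference between the two cores is not broken down here. In this assay compound 3 gives > 25000 nM, again a limit. Compound 4 `CC(C)(CCCN1CCN(c2ccncc2)C1=O)COc1ccc(-c2ccc(Cl)cc2)cc1` is not yet measured and differs from compound 3 by methyl in place of hydrogen on a saturated chain carbon bound to three saturated chain carbons. This is the same kind of change as from compound 2 to compound 1, but the place differs: there the carbon sits two bonds along the chain from an aromatic carbon, here it is bound to three saturated chain carbons. With the earlier step unreadable and every value a limit, the step expected in this assay is a number no higher from compound 3 to compound 4 (the limit leaves the size open). Compound 4 is estimated at 25000 nM in this assay, between 12500 nM and 50000 nM, most likely reported again as a limit.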

Compound 4, half-maximal cytotoxic concentration: > 25000 nM
Compound 4: no number, only a limit; the forecaster's own chance of this, stated with the estimate: 85%; the middle value lies on the limit itself.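

In this assay, compound 3 and compound 4 both give a limit of the test rather than a number, so no step can be read between them. The compounds shown leave open whether methyl in place of hydrogen changes the half-maximal cytotoxic concentration at either place, and by how much: none of their values is a number.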